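The source may hold more compounds than are shown below. What is called first, only, known or untested is meant among the compounds shown, and "the series" means these compounds.

Working notes on the series

Two compounds of the shared core have numbers in a functional assay on A549 cells (Homo sapiens) for cytotoxicity, read by MTT assay, with a stated time of 24 h (on this read-out lower numbers stand for stronger inhibition and higher numbers for weaker inhibition), so far. Compound 1 `Fc1ccc(-n2cc(COc3ccccc3-c3nc4ccccc4s3)nn2)cc1Cl` gives 16300 nM in this assay. Compound 2 `FC(F)(F)Oc1ccc(-c2cc(COc3ccccc3-c3nc4ccccc4s3)on2)cc1` gives 23900 nM in this assay. Compound 2 stands at the highest of the two numbers, and its nearest neighbour is compound 1, whose number is lower by a gap that lies within the scatter of repeated measurements, so the two values show no difference that can be read as order. Among the compounds with values here, no step between compounds that differ in one place is available in this set.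

Compound 3 `Brc1ccc(-c2cc(COc3ccccc3-c3nc4ccccc4s3)on2)cc1` is not yet measured in this assay. It differs from compound 2 in one place: bromo in place of trifluoromethoxy on an aromatic carbon, on an aromatic carbon of a six-membered aromatic ring of carbon only, para to a large group. Within the data shown here, with no measured step of this kind for comparison, the expectation rests only on the two values in hand, which sit close together. The step from compound 2 to compound 3 is expected to stay within the scatter, a 1.2-fold lower number from compound 2 to compound 3 (0.08 log units; within the scatter). For compound 3 the estimate in this assay is 20000 nM, with a range from 7000 nM to 55000 nM.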

Compound 3, half-maximal inhibitory concentration: 19200 nM
Compound 3: the middle estimate sits 1.0-fold (0.02 log units) above what was measured; the measured number falls inside the stated range.
By their numbers in this assay, from the lowest: compounds 1, 3 and 2 (each within the scatter of the next).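

Within the data shown here, the first comparison between compounds that differ in one place reads, in this assay, a 1.2-fold lower number from compound 2 to compound 3 (0.10 log units; within the scatter), and so gives this position its first direct reading. On an aromatic carbon of a six-membered aromatic ring of carbon only, para to a large group, trifluoromethoxy with 5 heavy atoms and 1 hydrogen-bond acceptor and bromo with 1 heavy atom and 0 hydrogen-bond acceptors give numbers that cannot be told apart. What can be taken from this single pair is limited to these two groups on this core, and no measurement is at hand that offers an explanation for the result.

Both groups have 0 hydrogen-bond donors and no net charge, so the compounds shown leave open whether an amine, a carboxylic acid or a longer alkyl chain at this position would give a number beyond the scatter. Also open, from the compounds shown here alone, is whether bromo in place of trifluoromethoxy would read the same way on the core of compound 1.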